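Cytotoxicity notes: thiazole in place of the acylthiourea

The compounds below may be only part of what the source reports. "The series", "measured", "known", "first", "only" and "open" are said of these compounds alone.

Compound 2 `CN(c1cc2ncc(=O)[nH]c2cc1NC(=S)NC(=O)c1ccco1)C1CCCCC1` gives 17300 nM in an ADME assay on Huh-7 cells (Homo sapiens) for cytotoxicity; a lower number here means a stronger inhibitor, a higher number a weaker inhibitor. Within the data shown here, the only other point is compound 1 `COc1cc(C(=O)NC(=S)Nc2cc3[nH]c(=O)cnc3cc2N(C)C2CCCCC2)cc(OC)c1OC`, which gives 15900 nM in this assay, and compound 2 and compound 1 lie within the scatter of each other: a 1.1-fold higher number from compound 1 to compound 2 (0.04 log units; within the scatter). Compound 3 `CN(c1cc2ncc(=O)[nH]c2cc1Nc1nc(-c2ccco2)cs1)C1CCCCC1` differs from compound 2 by a group of 10 heavy atoms (7 carbon, 1 nitrogen, 1 oxygen, 1 sulfur; one five-membered aromatic ring with 1 hetero atom, one five-membered aromatic ring with 2 hetero atoms) in place of a group of 10 heavy atoms (6 carbon, 1 nitrogen, 2 oxygen, 1 sulfur; one five-membered aromatic ring with 1 hetero atom), on a nitrogen on an aromatic ring. Among the measured compounds shown here, no measured step touches that part of the molecule, so nothing here bears on it; the one step seen shows the readout indifferent to the acyl group. The expectation is no change beyond the scatter for compound 3, a 1.1-fold lower number from compound 2 to compound 3 (0.03 log units; within the scatter). Compound 3 is estimated at 16000 nM, range 6000 nM to 45000 nM.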

Compound 3, half-maximal inhibitory concentration: 11900 nM
For compound 3 the middle estimate is 1.3-fold (0.13 log units) above the measured one; the measured number falls inside the stated range.
By their numbers in this assay, from the lowest: compounds 3, 1 and 2 (each within the scatter of the next).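

On the nitrogen on an aromatic ring, 4-(furan-2-yl)-1,3-thiazol-2-yl replaces the acylthiourea group with no change beyond the scatter in this assay: a 1.5-fold lower number from compound 2 to compound 3 (0.16 log units; within the scatter). The indifference seen so far only for the acyl group therefore extends to this larger change, which also removes both double bonds outside aromatic rings. No available evidence bears on the basis of this flat readout.

Open, as far as these compounds go, is whether the readout holds with an amine or a carboxylic acid in place of the furan-2-yl group on the thiazole. From the compounds shown here alone, all three compounds share the core, so its role remains untested.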